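Trifluoromethyl on the fused ring system: compound 4

This account rests on a few compounds, and the source may have more. Where it says the series, first, only, none or still open, it means among the compounds named here.

Among the measured compounds shown here, compound 3 `CCCCOC(=O)NS(=O)(=O)c1ccc(CCC)cc1-c1ccc(Cn2c(C3CC3)nc3ccccc32)cc1` gives 31 nM in an assay on membranes from HEK293 cells for displacement of a labelled ligand from Type-2 angiotensin II receptor (Homo sapiens), read by radioligand binding (a higher number here means a weaker inhibitor, a lower number a stronger inhibitor), and stands second highest of the three numbers so far; nearest is compound 1 `CCCCOC(=O)NS(=O)(=O)c1ccc(CCC)cc1-c1ccc(Cn2cnc3ccccc32)cc1` at 29 nM, furthest compound 2 `CCCCOC(=O)NS(=O)(=O)c1ccc(CCC)cc1-c1ccc(Cn2c(C3CCCCC3)nc3ccccc32)cc1` at 130 nM. The step of a 1.1-fold higher number from compound 1 to compound 3 (0.03 log units; within the scatter) lies within the scatter, whereas a 4.5-fold higher number from compound 1 to compound 2 (0.65 log units; beyond the scatter) and a 4.2-fold lower number from compound 2 to compound 3 (0.62 log units; beyond the scatter) are beyond it. Compound 4 `CCCCOC(=O)NS(=O)(=O)c1ccc(CCC)cc1-c1ccc(Cn2c(C(F)(F)F)nc3ccccc32)cc1` differs from compound 3 by trifluoromethyl in place of cyclopropyl on an aromatic carbon. For the measured compounds named here, no measured step covers trifluoromethyl at this aromatic carbon; the only guidance is that hydrogen and cyclopropyl read alike, while cyclohexyl raised the number. A step of a 1.3-fold higher number from compound 3 to compound 4 (0.11 log units; within the scatter) is therefore expected in this assay, not clearly beyond the scatter. Compound 4 is estimated at 40 nM, range 15 nM to 120 nM.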

Compound 4, inhibition constant: 13 nM
Beside the measured number, compound 4's estimate is 3.1-fold (0.49 log units) above it, and the stated range ends above it.
By their numbers in this assay, from the lowest: compound 4; then compounds 1 and 3 (each within the scatter of the next); then compound 2.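

In this assay, a group on this aromatic carbon can lower the number relative to hydrogen, with trifluoromethyl giving a 2.2-fold lower number from compound 1 to compound 4 (0.35 log units; beyond the scatter), whereas cyclopropyl read alike and cyclohexyl raised it. Exchanging a ring for trifluoromethyl also matters here, with a 2.4-fold lower number from compound 3 to compound 4 (0.38 log units; beyond the scatter) and a 10-fold lower number from compound 2 to compound 4 (1.00 log units; beyond the scatter). No evidence is available to explain these steps.

Open, going by these compounds, is whether the lower number is particular to trifluoromethyl or extends to other groups without a ring, such as methyl or a longer chain. On these data alone, how an amine on this carbon would read also remains open.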